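Compound 4 and rat clearance after an amide-group swap

A few compounds are considered here, and "the series" means these few. Any claim that something is new, unique, unknown or untested is made for them only; others in the source may bear on it.

Measured so far in an ADME assay on the whole organism (strain Sprague-Dawley) for pharmacokinetics, with Rattus norvegicus as the target, read by LC-MS, using cassette dosing, at a dose of 0.5 mg/kg by the intravenous route; on this read-out lower numbers stand for slow clearance and higher numbers for fast clearance:
Compound 1 `Cc1cc(C#N)cnc1C(=O)Nc1ccc(F)c([C@]2(C)C=C(CF)OC(N)=N2)c1` gives 21.8 mL/min/kg
Compound 2 `C[C@@]1(c2cc(NC(=O)c3cnc(C(F)F)cn3)ccc2F)C=C(CF)OC(N)=N1` gives 48.1 mL/min/kg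
Compound 3 `COc1cnc(C(=O)Nc2ccc(F)c([C@]3(C)C=C(CF)OC(N)=N3)c2)cn1` gives 64.9 mL/min/kg

Compound 3 shares the fast end of this small set with compound 2, as a 3.0-fold higher number from compound 1 to compound 3 (0.47 log units; beyond the scatter) and a 1.3-fold higher number from compound 2 to compound 3 (0.13 log units; within the scatter) show. Compound 4 `C[C@@]1(c2cc(NC(=O)c3coc(CF)n3)ccc2F)C=C(CF)OC(N)=N1` has 2-(fluoromethyl)-1,3-oxazol-4-yl in place of 5-methoxypyrazin-2-yl on a carbonyl carbon. The steps of a 2.2-fold higher number from compound 1 to compound 2 (0.34 log units; beyond the scatter) and a 3.0-fold higher number from compound 1 to compound 3 (0.47 log units; beyond the scatter) at this same place were modest, and no five-membered ring has been measured there. What is expected in this assay is a 1.4-fold lower number from compound 3 to compound 4 (0.16 log units; within the scatter) with nothing beyond the scatter. Compound 4 is estimated at 45 mL/min/kg (20 mL/min/kg to 85 mL/min/kg).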

Compound 4, clearance: 55 mL/min/kg
The estimate for compound 4 lay 1.2-fold (0.09 log units) below the measured number, within the range that was stated.
By their numbers in this assay, from the lowest: compound 1; then compounds 2, 4 and 3 (each within the scatter of the next).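

In this assay, a five-membered ring on the carbonyl carbon reads like the two pyrazinyl groups, with a 1.2-fold lower number from compound 3 to compound 4 (0.07 log units; within the scatter) and a 1.1-fold higher number from compound 2 to compound 4 (0.06 log units; within the scatter). Only the 5-cyano-3-methylpyridin-2-yl group stands apart, with a 2.5-fold higher number from compound 1 to compound 4 (0.40 log units; beyond the scatter), so among these four compounds, ring size does not separate the groups. Nothing shown gives a reason for these numbers. Still open, as far as these compounds go, is whether a methyl or a hydroxymethyl in place of the fluoromethyl on the oxazole would change clearance. A nitrile on the oxazole is also untested among the compounds shown here.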